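Replacing the carboxyphenyl amide with an acetylphenyl amide

The source may report more compounds than this note shows. Statements on the series, on what has been measured and on what is new or still open speak of the compounds shown alone.

Of the compounds shown here, three built on a shared core have been measured in a functional assay on CLL cells (Homo sapiens) for cytotoxicity, read by MTT assay, with a stated time of 48 h; on this read-out higher numbers stand for an effect only at larger amounts of compound and lower numbers for an effect already at smaller amounts. Compound 1 `C=C(CC)C(=O)c1ccc(OCC(=O)Nc2cccc(C(=O)O)c2)c(Cl)c1Cl` gives 20600 nM, the highest of the three numbers. Among the compounds with values here, compound 2 `C=C(CC)C(=O)c1ccc(OCC(=O)Nc2ccc(Cl)c(C(=O)O)c2)c(Cl)c1Cl` gives 15900 nM, and the step of a 1.3-fold lower number from compound 1 to compound 2 (0.11 log units; within the scatter) is the only single-point change among the measured compounds. Compound 3 `C=C(CC)C(=O)c1ccc(OCC(=O)Nc2ccc(C(=O)NC(CCC(=O)OCC)C(=O)OCC)cc2)c(Cl)c1Cl` gives 2100 nM; it carries no free carboxylic acid on the amide-linked ring, and its number lies well beyond the scatter from that of compound 1, though the two structures differ in more than one place.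

Compound 4 `C=C(CC)C(=O)c1ccc(OCC(=O)Nc2ccc(C(C)=O)cc2)c(Cl)c1Cl` has not yet been measured in this assay. It differs from compound 1 in one place: 4-acetylphenyl in place of 3-carboxyphenyl on an amide-type nitrogen. The change removes the hydrogen-bond donor of the carboxylic acid, as compound 3 also lacks a free acid. Within the data shown here, no measured step covers exactly this change; the step from compound 1 to compound 2 leaves the acid in place and is within the scatter, so it offers no direction. The pairing of compound 1 with compound 3 suggests that losing the free acid may go with a lower number, but that comparison is confounded by the larger substituent.

He therefore expects a moderate drop, a 2.9-fold lower number from compound 1 to compound 4 (0.47 log units; beyond the scatter), and estimates compound 4 at 7000 nM, within the range 2000 nM to 25000 nM.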

Compound 4, half-maximal effective concentration: 3900 nM
For compound 4 the middle estimate is 1.8-fold (0.25 log units) above the measured one; measured number inside the range.
By their numbers in this assay, from the lowest: compounds 3 and 4 (each within the scatter of the next); then compounds 2 and 1 (each within the scatter of the next).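

In this assay, within the data shown here, the step of a 5.3-fold lower number from compound 1 to compound 4 (0.72 log units; beyond the scatter) is the first single-place change on the shared core to lie beyond the scatter, whereas the chloro step a 1.3-fold lower number from compound 1 to compound 2 (0.11 log units; within the scatter) stays within it. The substituent on the amide-type nitrogen is therefore a place where the number does respond, and this exchange keeps the count of 9 heavy atoms and the aromatic ring while the hydrogen-bond donor goes, showing that a free carboxylic acid on this ring is not required for a lower number. No measurement shown here bears on what lies behind this step.

The carboxylic acid gave way to an acetyl group and the substituent went from the 3- to the 4-position in the same step, which leaves open which of the two changes carries the difference. On these data alone, a 3-acetylphenyl or a 4-carboxyphenyl on the same nitrogen would separate them, and whether an amine or a longer acyl chain in place of the acetyl group would move the number in the same direction also remains open.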